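Three values at the assay limit, and a fourth compound

The source may hold more compounds than are shown below. What is called first, only, known or untested is meant among the compounds shown, and "the series" means these compounds.

Compound 1 `O=C1CNC(=O)N1C[C@H]1CN(c2ccc(-n3cc(-c4ccccn4)cn3)c(F)c2)C(=O)O1` gives > 400 ug/mL in an ADME assay on HEK293-A cells (Homo sapiens) for cytotoxicity, read by MTT assay, with a stated time of 48 h (on this read-out higher numbers stand for weaker inhibition and lower numbers for stronger inhibition), which is a limit of the assay and not a number.
Compound 2 `CC(=O)OC[C@H]1CN(c2ccc(-n3cc(-c4ccccn4)cn3)c(F)c2)C(=O)O1` gives > 400 ug/mL in this assay, again a limit.
Compound 3 `COC[C@H]1CN(c2ccc(-n3cc(-c4ccccn4)cn3)c(F)c2)C(=O)O1` gives > 400 ug/mL in this assay, also a limit.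

Compound 3 therefore stands only as a limit, at the same mark as the other two, (the limit of > 400 ug/mL in this assay, at which 3 of the 3 values shown sit). The measured steps are all unreadable for the same reason: a step that the two limits leave unreadable from compound 1 to compound 2, a step that the two limits leave unreadable from compound 1 to compound 3 and a step that the two limits leave unreadable from compound 2 to compound 3. Compound 4 `CNC(=O)[C@H]1CN(c2ccc(-n3cc(-c4ccccn4)cn3)c(F)c2)C(=O)O1` is the one not yet measured. It differs from compound 3 in one place: methylcarbamoyl in place of methoxymethyl on a saturated ring carbon. The steps from compound 1 to compound 3 and from compound 2 to compound 3 change the group on the same saturated ring carbon, so they bear on this change, but neither gives a size. With every measured value sitting at the limit, compound 4 is expected to sit there as well, and the step of a number no higher from compound 3 to compound 4 (the limit leaves the size open) is expected to be none beyond the scatter. The estimate for compound 4 is 400 ug/mL, within 150 ug/mL to 400 ug/mL.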

Compound 4, half-maximal inhibitory concentration: 342 ug/mL
Estimate against measurement, compound 4: 1.2-fold (0.07 log units) above; measured number inside the range.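

In this assay, within the data shown here, compound 4 gives 342 ug/mL as a measured number rather than a limit, the first such number with a group on the saturated ring carbon next to the ring oxygen. That number yields an at least 1.1-fold lower number from compound 3 to compound 4 (0.06 log units; that floor lies within the scatter) and an at least 1.1-fold lower number from compound 2 to compound 4 (0.06 log units; that floor lies within the scatter) and an at least 1.1-fold lower number from compound 1 to compound 4 (0.06 log units; that floor lies within the scatter) as readable steps, but each is only a floor, so no real shift can be claimed for methylcarbamoyl, and the steps among the three earlier compounds cannot be read. The earlier compounds shown here remain limits of the assay: the limit of > 400 ug/mL in this assay, at which 3 of the 4 values shown sit.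

Going by these compounds, the true size of each step stays open, since the limits give no upper end. On these data alone, what an amine, a carboxylic acid or a longer chain on this ring carbon would give also stays open.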